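Fluorobenzyl to Methoxybenzyl on a Shared Amide Core

A few compounds are considered here, and "the series" means these few. Any claim that something is new, unique, unknown or untested is made for them only; others in the source may bear on it.

Among the compounds with values here, compound 2 `O=C(N[C@H]1CCN(Cc2ccc(F)cc2)C1)c1ccc(-c2cccs2)cc1` gives the lowest of the two numbers so far in an assay on HEK298 cells for displacement of a labelled ligand from D(4) dopamine receptor (Homo sapiens) (a lower number here means a stronger inhibitor, a higher number a weaker inhibitor), at 5 nM. Compound 1 `O=C(N[C@H]1CCN(Cc2ccc(C(F)(F)F)cc2)C1)c1ccc(-c2cccs2)cc1` gives 14 nM in this assay, and the step of a 2.8-fold lower number from compound 1 to compound 2 (0.45 log units; beyond the scatter) shows that a change on this benzyl ring can move the number. Compound 3 `COc1cccc(CN2CC[C@H](NC(=O)c3ccc(-c4cccs4)cc3)C2)c1` carries the change (3-methoxyphenyl in place of 4-fluorophenyl on a saturated chain carbon bound to an amine nitrogen in a ring). Within the data shown here, only that measured step bears on it, and only loosely, since it alters a different group. A modest step is expected, a 1.6-fold higher number from compound 2 to compound 3 (0.20 log units; within the scatter). Compound 3 is therefore estimated at 8 nM in this assay, within 2.5 nM to 25 nM.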

Compound 3, inhibition constant: 14 nM
The estimate for compound 3 lay 1.8-fold (0.24 log units) below the measured number; the range from low to high includes it.
By their numbers in this assay, from the lowest: compound 2; then compounds 1 and 3 (each within the scatter of the next).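

In this assay, 3-methoxyphenyl in place of 4-fluorophenyl gives a 2.8-fold higher number from compound 2 to compound 3 (0.45 log units; beyond the scatter), while 3-methoxyphenyl in place of 4-(trifluoromethyl)phenyl gives no change at the digits printed from compound 1 to compound 3 (within the scatter). Among these three benzyl groups, then, only the 4-fluorobenzyl of compound 2 stands apart, and two quite different replacements give the same printed number. Nothing available explains this result. The compounds shown leave open whether the methoxy group itself or its place on the ring matters, and how 4-methoxyphenyl, 3-fluorophenyl or an aminophenyl group would read here.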